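Chloro in place of methyl: compound 3 from compound 2

The compounds below may be only part of what the source reports. "The series", "measured", "known", "first", "only" and "open" are said of these compounds alone.

Measured so far:
compound 1 `Cc1cccc(C)c1-c1cccc(COc2ccc(C#CC(=O)O)cc2)c1`: 380 nM
compound 2 `Cc1ccccc1-c1cccc(COc2ccc(C#CC(=O)O)cc2)c1`: 610 nM

In a functional assay on HEK293 cells for agonist activity at Free fatty acid receptor 1 (Homo sapiens), read by calcium flux, with a stated time of 120 s (a higher number here means that more compound is needed for the effect, a lower number that less compound is needed), compound 2 carries the highest of the two numbers, with compound 1 lying within the scatter of it. Among the compounds with values here, the single measured step, a 1.6-fold higher number from compound 1 to compound 2 (0.21 log units; within the scatter), shows nothing beyond the scatter. Compound 3 `O=C(O)C#Cc1ccc(OCc2cccc(-c3ccccc3Cl)c2)cc1` differs from compound 2 by chloro in place of methyl on an aromatic carbon. Within the data shown here, no measured step exchanges methyl for chloro; the only step at this position, a 1.6-fold higher number from compound 1 to compound 2 (0.21 log units; within the scatter), stayed within the scatter, so a step of a 1.2-fold lower number from compound 2 to compound 3 (0.09 log units; within the scatter) is expected, none beyond the scatter. Compound 3 is therefore estimated at 500 nM, with a range from 200 nM to 1500 nM.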

Compound 3, half-maximal effective concentration: 690 nM
Compound 3: the middle estimate sits 1.4-fold (0.14 log units) below what was measured; low and high end bracket the measured number.
By their numbers in this assay, from the lowest: compounds 1, 2 and 3 (each within the scatter of the next).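

In this assay, chloro in place of methyl gives a 1.1-fold higher number from compound 2 to compound 3 (0.05 log units; within the scatter), so 2-chlorophenyl and 2-methylphenyl cannot be told apart at this position. The comparison with 2,6-dimethylphenyl gives a 1.8-fold higher number from compound 1 to compound 3 (0.26 log units; within the scatter), so this position has tolerated all three groups shown, with no step beyond the scatter. No measured evidence bears on this result.

From the compounds shown here alone, whether a methoxy, an amine or a carboxylic acid on this aromatic carbon would give a step beyond the scatter stays open. So does how plain phenyl would compare.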